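Amide variation on the nitrocatechol cyanoacrylamide series

This account rests on a few compounds, and the source may have more. Where it says the series, first, only, none or still open, it means among the compounds named here.

Compound 1 `N#C/C(=C\c1cc(O)c(O)c([N+](=O)[O-])c1)C(=O)N(c1ccccc1)c1ccccc1` in a functional assay on BGC-823 cells (Homo sapiens) for antiproliferative activity, read by MTT assay (a lower number here means a stronger inhibitor, a higher number a weaker inhibitor), gives > 100 ug/mL, which is a limit of this assay and not a number.
Compound 2 `Cc1cccc(NC(=O)/C(C#N)=C/c2cc(O)c(O)c([N+](=O)[O-])c2)c1` in this assay gives 5.6 ug/mL.
Compound 3 `N#C/C(=C\c1cc(O)c(O)c([N+](=O)[O-])c1)C(=O)Nc1cccc(Cl)c1` in this assay gives > 100 ug/mL, again a limit rather than a number.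

Among the compounds with values here, compound 2 thus holds the only number in this assay; the other two values sit at the limit (the limit of > 100 ug/mL in this assay, at which 2 of the 3 values shown sit). Within the data shown here, the single step that can be sized, an at least 17-fold higher number from compound 2 to compound 3 (1.25 log units; beyond the scatter), is large. Compound 1, in which the amide hydrogen is absent, also reaches only the limit (the limit of > 100 ug/mL in this assay, at which 2 of the 3 values shown sit).

Compound 4 `N#C/C(=C\c1cc(O)c(O)c([N+](=O)[O-])c1)C(=O)N1CCOCC1` differs from compound 2 by morpholin-4-yl in place of (3-methylphenyl)amino on a carbonyl carbon. Among the measured compounds shown here, this change removes the amide hydrogen and the aromatic ring at the carbonyl carbon, so in kind it stands closer to the change seen in compound 1 than to that in compound 3; no measured step covers it directly. Since both neighbours of compound 2 sit at the limit (the limit of > 100 ug/mL in this assay, at which 2 of the 3 values shown sit), and since an at least 17-fold higher number from compound 2 to compound 3 (1.25 log units; beyond the scatter) is large, a step toward a higher number is expected, an 11-fold higher number from compound 2 to compound 4 (1.03 log units; beyond the scatter), with a real chance that only the limit is reported. The estimate for compound 4 is 60 ug/mL, with a range from 8 ug/mL to 300 ug/mL.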

Compound 4, half-maximal inhibitory concentration: > 100 ug/mL
Compound 4: a limit, no number (the forecaster's own chance of this, stated with the estimate: 55%); middle value at least 1.6-fold (0.22 log units) away from the limit.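

In this assay, morpholin-4-yl in place of (3-methylphenyl)amino on a carbonyl carbon gives an at least 17-fold higher number from compound 2 to compound 4 (1.25 log units; beyond the scatter), a large step that shows that this non-aromatic ring with its ring oxygen does not keep the activity of compound 2. Compound 4 gives > 100 ug/mL, which is a limit and not a number. Among the groups shown on this carbonyl carbon, only the (3-methylphenyl)amino of compound 2 gives a number, and the step from compound 3 to compound 4 cannot be read, since both values are limits; the series now stands as follows: the limit of > 100 ug/mL in this assay, at which 3 of the 4 values shown sit.

This change removes the amide hydrogen and the aromatic ring in a single step, and the compounds shown do not separate the two. Cyclohexylamino on the carbonyl carbon would keep the amide hydrogen without the aromatic ring and methyl(3-methylphenyl)amino would keep the aromatic ring without the amide hydrogen, and it remains open how either would read in this assay.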